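A few compounds are considered here, and "the series" means these few. Any claim that something is new, unique, unknown or untested is made for them only; others in the source may bear on it.

Compound 1 `CSc1cc(/C=C/c2ccc(OCc3ccccc3)cc2)nc(N)n1`: 376000 nM
Compound 2 `CSc1cc(/C=C/c2ccc(OS(=O)(=O)O)cc2)nc(N)n1`: 301000 nM

Going by the values given here, in an ADME assay on Vero cells (Chlorocebus sabaeus) for cytotoxicity, read by MTT assay, with a stated time of 72 h (a higher number here means that more compound is tolerated, a lower number that less compound is tolerated), compound 1 stands level with compound 2, the only other compound measured: the step is a 1.2-fold lower number from compound 1 to compound 2 (0.10 log units; within the scatter). Compound 3 `COc1ccc(Nc2cc(/C=C/c3ccc(OCc4ccccc4)cc3)nc(N)n2)cc1` differs from compound 1 at another place, with (4-methoxyphenyl)amino in place of methylsulfanyl on an aromatic carbon. Among the compounds with values here, the step to compound 2 changes only the group on the oxygen, so no measured step covers this place, and the expectation is loose. A moderate step to a lower number is expected: a 2.2-fold lower number from compound 1 to compound 3 (0.34 log units; beyond the scatter). For compound 3 the estimated value is 170000 nM, with an expected range of 50000 nM to 450000 nM.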

Compound 3, half-maximal cytotoxic concentration: 57800 nM
Compound 3: the middle estimate sits 2.9-fold (0.47 log units) above what was measured, within the range that was stated.
By their numbers in this assay, from the lowest: compound 3; then compounds 2 and 1 (each within the scatter of the next).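

In this assay, replacing methylsulfanyl with (4-methoxyphenyl)amino on this aromatic carbon gives a 6.5-fold lower number from compound 1 to compound 3 (0.81 log units; beyond the scatter), so this position responds beyond the scatter, whereas the change on the oxygen, a 1.2-fold lower number from compound 1 to compound 2 (0.10 log units; within the scatter), did not. Nothing available bears on why the number falls. The compounds shown leave open whether the step goes with the amino link or with the 4-methoxyphenyl ring it carries. A methylamino or an unsubstituted phenylamino group on the same carbon would help to separate the two.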